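A few compounds are considered here, and "the series" means these few. Any claim that something is new, unique, unknown or untested is made for them only; others in the source may bear on it.

Compound 1 `Cc1ccc(C2CNN=C2S(=O)(=O)CC2=NCCS2)cc1` and compound 3 `Cc1ccc(C2CNN=C2S(=O)(=O)CC2=NCCO2)cc1` share one core. In a functional assay, tested at 75 ug/mL (a higher number here means a stronger effect of the compound at the concentration tested, a lower number a weaker effect), compound 1 gives 42.2%, and in this assay compound 3 gives 42.1%. The step of a number 0.1 percentage points lower from compound 1 to compound 3 (within the scatter) comes with the change (a group of 5 heavy atoms (3 carbon, 1 nitrogen, 1 oxygen; one five-membered non-aromatic ring with 2 hetero atoms) in place of a group of 5 heavy atoms (3 carbon, 1 nitrogen, 1 sulfur; one five-membered non-aromatic ring with 2 hetero atoms), on a saturated chain carbon bound to a sulfonyl sulfur). Compound 2 `Cc1ccc(-c2c[nH]nc2S(=O)(=O)CC2=NCCS2)cc1` has a different core; how the two cores differ is not broken down here. In this assay compound 2 gives "not active" (no number reported), with no number behind that report. Compound 4 `Cc1ccc(-c2c[nH]nc2S(=O)(=O)CC2=NCCO2)cc1`, not yet measured, carries the same change on the core of compound 2: a group of 5 heavy atoms (3 carbon, 1 nitrogen, 1 oxygen; one five-membered non-aromatic ring with 2 hetero atoms) in place of a group of 5 heavy atoms (3 carbon, 1 nitrogen, 1 sulfur; one five-membered non-aromatic ring with 2 hetero atoms), on a saturated chain carbon bound to a sulfonyl sulfur. Since that change left compound 1 and compound 3 within the scatter, as a number 0.1 percentage points lower from compound 1 to compound 3 (within the scatter) shows, compound 4 is expected to stay near compound 2, which gave no activity. Compound 4 is therefore estimated at 8%, within 0% to 25%.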

Compound 4, a percentage reported as activity, at one concentration (the size of the read-out at that concentration, not a potency): 62%
The estimate for compound 4 lay 54 percentage points below the measured number; measured number outside the range, above it.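

Among the compounds shown here, compound 2 carries no number, so no step from it to compound 4 can be read. The compounds shown leave open what separates compound 4 from compound 2, and no available evidence bears on this.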